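Moving one chlorine on the benzyl ether of compound 3

This account rests on a few compounds, and the source may have more. Where it says the series, first, only, none or still open, it means among the compounds named here.

Measured compounds:
Compound 1 `O=C(NC(=S)Nc1ccc(Cl)c(-c2nc3ccccc3[nH]2)c1)c1ccc(OCc2ccc(Cl)c(Cl)c2)cc1` — 4930 nM
Compound 2 `Cc1ccc(NC(=O)NC(=O)c2ccc(OCc3ccccc3)cc2)cc1-c1nc2ccccc2[nH]1` — 16400 nM
Compound 3 `Cc1ccc(NC(=O)NC(=O)c2ccc(OCc3cccc(Cl)c3Cl)cc2)cc1-c1nc2ccccc2[nH]1` — 48500 nM

These three compounds were tested in a functional assay on HT-29 cells (Homo sapiens) for inhibition, read by MTT assay, with a stated time of 48 h; on this read-out higher numbers stand for weaker inhibition and lower numbers for stronger inhibition. Compound 3 gives the highest number of the three. Its nearest neighbour is compound 2, and the step of a 3.0-fold higher number from compound 2 to compound 3 (0.47 log units; beyond the scatter) is beyond the scatter. Compound 1 lies furthest away, and compound 1 and compound 3 also differ in the core, so their two values are simply shown side by side.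

Compound 4 `Cc1ccc(NC(=O)NC(=O)c2ccc(OCc3ccc(Cl)cc3Cl)cc2)cc1-c1nc2ccccc2[nH]1` has not yet been measured. It differs from compound 3 only in the benzyl ether: 2,4-dichlorophenyl in place of 2,3-dichlorophenyl on a saturated chain carbon bound to an oxygen on an aromatic ring. For the measured compounds named here, no measured step describes this kind of change. Going by the values given here, the only step at the same place, from phenyl to 2,3-dichlorophenyl, is a 3.0-fold higher number from compound 2 to compound 3 (0.47 log units; beyond the scatter), which is modest. Shifting one chlorine within an already dichlorinated ring is a smaller change than adding both chlorines, so in this assay the expected step is one that stays within the scatter, with no clear direction, as a 1.2-fold lower number from compound 3 to compound 4 (0.08 log units; within the scatter). Compound 4 is therefore estimated at 40000 nM, with a range from 15000 nM to 110000 nM.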

Compound 4, half-maximal inhibitory concentration: 2620 nM
The estimate for compound 4 lay 15-fold (1.18 log units) above the measured number, outside the stated range (below it).
By their numbers in this assay, from the lowest: compounds 4 and 1 (each within the scatter of the next); then compound 2; then compound 3.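

In this assay, this place on the benzyl ether responds not just to whether chlorines are present but to how they are arranged on the ring. The atom count stays the same, yet 2,4-dichlorophenyl in place of 2,3-dichlorophenyl gives (a 19-fold lower number from compound 3 to compound 4 (1.27 log units; beyond the scatter)), a large step from a change that only moves one chlorine. Compared with the plain phenyl group, the two dichlorinated rings also pull in opposite directions, since one raises the number (a 3.0-fold higher number from compound 2 to compound 3 (0.47 log units; beyond the scatter)) and the other lowers it (a 6.3-fold lower number from compound 2 to compound 4 (0.80 log units; beyond the scatter)), and no available measurement accounts for this difference.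

Going by these compounds, with only these two dichlorinated rings to compare, it remains open which chlorine drives the step, and how a single chlorine, a fluorine or a methoxy group at this place would read. It is also unknown whether 2,4-dichlorophenyl would give a similar result on the core of compound 1, or whether the pattern would carry over to any other cell line.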